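The source may report more compounds than this note shows. Statements on the series, on what has been measured and on what is new or still open speak of the compounds shown alone.

Compound 2 `Cc1cc(-c2cccc(S(=O)(=O)NC(=O)[C@@H](N)CC(C)C)c2)ncn1` gives 2000 nM in an assay on isolated protein for inhibition of leucine--tRNA ligase, cytoplasmic (Homo sapiens); on this read-out higher numbers stand for weaker inhibition and lower numbers for stronger inhibition. For the measured compounds named here, of the two numbers measured so far it is the lower one, but compound 1 `CC(C)C[C@H](N)C(=O)NS(=O)(=O)c1cccc(-c2ccccc2)c1` with 3400 nM lies within the scatter of it, so the two cannot be told apart. Going by the values given here, the only measured change, a 1.7-fold lower number from compound 1 to compound 2 (0.23 log units; within the scatter), exchanged one aromatic group for another of similar size. Compound 3 `CC(C)C[C@H](N)C(=O)NS(=O)(=O)c1ccccc1` carries hydrogen in place of 6-methylpyrimidin-4-yl on an aromatic carbon: the whole 6-methylpyrimidin-4-yl group is taken away and nothing but hydrogen remains where it stood. Among the compounds with values here, no measured step covers the loss of this group altogether; the one available step only exchanged phenyl for it. Both measured compounds carry a group at this place, and removing it is expected to weaken inhibition, so a step of a 5.0-fold higher number from compound 2 to compound 3 (0.70 log units; beyond the scatter) is expected. Compound 3 is therefore estimated at 10000 nM, within a range from 2500 nM to 40000 nM.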

Compound 3, half-maximal inhibitory concentration: 1100 nM
The estimate for compound 3 lay 9.1-fold (0.96 log units) above the measured number; measured number below the stated range.
By their numbers in this assay, from the lowest: compounds 3, 2 and 1 (each within the scatter of the next, the first and the last beyond it).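

The step of a 1.8-fold lower number from compound 2 to compound 3 (0.26 log units; within the scatter) in this assay shows that the 6-methylpyrimidin-4-yl group is not needed for inhibition at this level, since hydrogen alone on this aromatic carbon cannot be told apart from it. For the compounds shown here, the step of a 3.1-fold lower number from compound 1 to compound 3 (0.49 log units; beyond the scatter) is the first in this set to lie beyond the scatter, so with phenyl at this place inhibition is modestly weaker than with hydrogen. No measurement at hand explains this result.

It remains open whether any group at this place can give a lower number than hydrogen, as both groups shown are six-membered aromatic rings. A single methyl, an amine or a carboxylic acid on this carbon would test that.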